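Tertiary amine in place of the branched secondary amine on the core

A few compounds are considered here, and "the series" means these few. Any claim that something is new, unique, unknown or untested is made for them only; others in the source may bear on it.

Compound 2 `CCCC(CCC)Nc1nc(C)nc2c1nnn2-c1ccc(Br)cc1Br` gives 0.8 nM in an in vitro assay on 293-EBNA cells for binding affinity to corticotropin-releasing factor receptor 1 (Homo sapiens) (a lower number here means a stronger inhibitor, a higher number a weaker inhibitor), the lowest of the three numbers in hand. Within the data shown here, compound 1 `CCCC(CCC)Nc1nc(C)nc2c1nnn2-c1c(C)cc(C)cc1C` gives 4 nM, and the step of a 5.0-fold lower number from compound 1 to compound 2 (0.70 log units; beyond the scatter) is the only single-point change measured. Compound 3 `COCC(COC)Nc1nc(C)nc2c1nnn2-c1ccc(C(C)C)cc1Br` gives 10.3 nM, but it differs from compound 2 in two places, so its value alone is taken. Compound 4 `CCCCN(CC)c1nc(C)nc2c1nnn2-c1ccc(Br)cc1Br` carries butyl(ethyl)amino in place of (1-propylbutyl)amino on an aromatic carbon, giving up the one hydrogen-bond donor. Among the measured compounds shown here, no measured step bears on this position, so the expectation rests on the series as a whole: a modest weakening is estimated, a 3.8-fold higher number from compound 2 to compound 4 (0.57 log units; beyond the scatter), within a wide band. Compound 4 is therefore expected to give 3 nM in this assay, between 0.8 nM and 12 nM.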

Compound 4, inhibition constant: 20.4 nM
For compound 4 the middle estimate is 6.8-fold (0.83 log units) below the measured one; measured number above the stated range.
By their numbers in this assay, from the lowest: compound 2; then compound 1; then compounds 3 and 4 (each within the scatter of the next).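

At this position, on the shared core with the 2,4-dibromophenyl group, the affinity is sensitive to the amine: replacing (1-propylbutyl)amino with butyl(ethyl)amino gives a 26-fold higher number from compound 2 to compound 4 (1.41 log units; beyond the scatter) in this assay. The step removes the hydrogen-bond donor and also changes the chain, going from 8 heavy atoms to 7, so this single pair cannot separate the two changes. Nothing available accounts for the loss.

Still open, from the compounds shown here alone, is whether a secondary amine with a shorter branched chain, such as (1-ethylpropyl)amino, would stay close to compound 2. A cyclic tertiary amine such as pyrrolidine is also unplaced.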